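This account rests on a few compounds, and the source may have more. Where it says the series, first, only, none or still open, it means among the compounds named here.

Measured compounds:
Compound 1 `CNc1nc(C)c(C(=O)N/N=C/c2cccc(C(F)(F)F)c2)s1` gives > 100 ug/mL in this assay, which is a limit and not a number.
Compound 2 `CNc1nc(C)c(C(=O)N/N=C/c2cc(C(F)(F)F)cc(C(F)(F)F)c2)s1` gives > 100 ug/mL, again a limit and not a number.
Compound 3 `CN(C(=O)NC(=O)c1ccc(C(F)(F)F)cc1)c1nc(C(F)(F)F)c(C(=O)N/N=C/c2ccc(C(F)(F)F)cc2)s1` gives > 100 ug/mL, also a limit and not a number.

All three were tested in a functional assay on BCG823 cells (Homo sapiens) for inhibition, read by MTT assay, with a stated time of 72 h; a higher number here means a weaker inhibitor, a lower number a stronger inhibitor. Compound 2 therefore stands only at a limit, and no number places it anywhere on a scale; the two other values shown are limits of the same kind. Going by the values given here, the one pair that differs in a single place, compound 1 and compound 2, gives a step that the two limits leave unreadable from compound 1 to compound 2, a step that cannot be read because both ends sit at the limit of > 100 ug/mL in this assay, at which 3 of the 3 values shown sit.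

The unmeasured compound 4 `CNc1nc(C(F)(F)F)c(C(=O)N/N=C/c2cc(C(F)(F)F)cc(C(F)(F)F)c2)s1` differs from compound 2 by trifluoromethyl in place of methyl on an aromatic carbon. No measured step concerns a change on the core, and the only measured step is unreadable, so nothing shown bears directly on this change; at the same time every value so far sits at the same limit. Compound 4 is therefore expected to give about 150 ug/mL, with a range from 50 ug/mL to 500 ug/mL. The expected step that the limit leaves unreadable from compound 2 to compound 4 is accordingly none beyond the scatter, and most likely a further limit rather than a number.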

Compound 4, half-maximal inhibitory concentration: > 100 ug/mL
Compound 4 gave a limit, no number (the forecaster's own chance of this, stated with the estimate: 80%); the middle value is on the limit's open side.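

Going by these compounds alone, compound 4 gives a limit and not a number, just as compound 2 does, so no step between compound 2 and compound 4 can be read: (the limit of > 100 ug/mL in this assay, at which 4 of the 4 values shown sit). The compounds shown leave open whether any of them has a measurable value in this assay and how a change in structure would shift such a value.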